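A few compounds are considered here, and "the series" means these few. Any claim that something is new, unique, unknown or untested is made for them only; others in the source may bear on it.

Measured so far:
- compound 1 `COc1ccc(/C=C/C(=O)c2ccco2)cc1Br`: 10900 nM
- compound 2 `O=C(/C=C/c1ccc(N2CCCC2)cc1)c1ccc(O)cc1`: 1370 nM
- compound 3 `COc1ccc(/C=C/C(=O)c2ccc(O)cc2)cc1Br`: "not determined" (no result reported)

In a functional assay on T47D cells (Homo sapiens) for cytotoxicity, read by MTT assay (on this read-out lower numbers stand for stronger inhibition and higher numbers for weaker inhibition), compound 1 has the higher of the two numbers, and compound 2 lies lower, by a gap beyond the scatter. Compound 3 gave no number, so it adds nothing to this comparison.

Next is compound 4 `COc1ccc(/C=C/C(=O)c2cccs2)cc1Br`, which differs from compound 1 as follows: thiophen-2-yl in place of furan-2-yl on a carbonyl carbon. Going by the values given here, no measured pair shows this exchange, so the expectation rests only on compound 1 at 10900 nM and on the close match of the two rings in the counts. No step beyond the scatter is expected in this assay, with at most a slight drift towards a lower number. The estimated step is a 1.3-fold lower number from compound 1 to compound 4 (0.11 log units; within the scatter). For compound 4 the expected value is 8500 nM, within an estimated range of 3500 nM to 21000 nM.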

Compound 4, half-maximal inhibitory concentration: 21900 nM
Estimate against measurement, compound 4: 2.6-fold (0.41 log units) below; measured number outside the range, above it.
By their numbers in this assay, from the lowest: compound 2; then compounds 1 and 4 (each within the scatter of the next).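

In this assay, going by these compounds alone, the exchange of furan-2-yl for thiophen-2-yl on a carbonyl carbon gives a 2.0-fold higher number from compound 1 to compound 4 (0.30 log units; within the scatter) and is the first step read at this position. The two rings are therefore not separated by this read-out, and the position tolerates this exchange without a change beyond the scatter. No measurement at hand offers an explanation for this pair. Still open, from the compounds shown here alone, is whether an amine or a longer chain on this carbonyl carbon would give a step beyond the scatter.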